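From cyclopentyl to phenyl on the oxygen

The source may hold more compounds than are shown below. What is called first, only, known or untested is meant among the compounds shown, and "the series" means these compounds.

For the measured compounds named here, in a functional assay on M21 cells (Homo sapiens) for inhibition, read by sulforhodamine B assay, with a stated time of 48 h (on this read-out higher numbers stand for weaker inhibition of growth and lower numbers for stronger inhibition of growth), compound 2 `c1cc(OC2CCCC2)ccc1NC1=NCCO1` gives 21100 nM, the higher of the two numbers so far, while compound 1 `c1ccc(-c2ccc(NC3=NCCO3)cc2)cc1` gives 8800 nM. Compound 3 `c1ccc(Oc2ccc(NC3=NCCO3)cc2)cc1` has phenyl in place of cyclopentyl on an oxygen on an aromatic ring. Going by the values given here, only one measured step bears on this change: a 2.4-fold higher number from compound 1 to compound 2 (0.38 log units; beyond the scatter), with cyclopentyloxy in place of phenyl on an aromatic carbon. That step is modest and involves a different place, so a similarly modest move towards a lower number is expected in this assay: a 2.1-fold lower number from compound 2 to compound 3 (0.32 log units; beyond the scatter). Compound 3 is estimated at 10000 nM, with an expected range of 4500 nM to 22000 nM.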

Compound 3, concentration for 50% growth inhibition: 3100 nM
Compound 3: middle estimate off by 3.2-fold (0.51 log units), on the high side; the measured number lies below the stated range.
By their numbers in this assay, from the lowest: compound 3; then compound 1; then compound 2.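

In this assay, phenyl in place of cyclopentyl on the oxygen gives a 6.8-fold lower number from compound 2 to compound 3 (0.83 log units; beyond the scatter), so the group on this oxygen clearly affects growth inhibition, which the earlier step on an aromatic carbon could not show. Ring size and aromatic character change together in this swap, so their contributions cannot be separated. Nothing measured here explains the difference.

Cyclohexyl on the same oxygen would keep the six-membered ring without the aromatic character, and its effect remains open. So does the effect of an amine or a carboxylic acid on the phenyl ring.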